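Swapping ethoxycarbonyl for ethoxymethyl on compound 3

The compounds below may be only part of what the source reports. "The series", "measured", "known", "first", "only" and "open" are said of these compounds alone.

- compound 1 `Cc1nc2cnccc2n1CC1CCN(C(=O)N[C@H](C)c2ccccc2)CC1`: 13 nM
- compound 2 `CCOC(=O)[C@H](CC(C)C)NC(=O)N1CCC(Cn2c(C)nc3cnccc32)CC1`: 12 nM
- compound 3 `CCOC(=O)[C@@H](NC(=O)N1CCC(Cn2c(C)nc3cnccc32)CC1)c1ccccc1`: 16 nM

In a functional assay (plasma) with Oryctolagus cuniculus as the target (on this read-out higher numbers stand for weaker inhibition and lower numbers for stronger inhibition), compound 3 gives 16 nM, and nothing separates it from the other two, since every step among the three stays within the scatter. The next structure, compound 4 `CCOC[C@@H](NC(=O)N1CCC(Cn2c(C)nc3cnccc32)CC1)c1ccccc1`, has ethoxymethyl in place of ethoxycarbonyl on a saturated chain carbon bound to an amide-type nitrogen and an aromatic carbon.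

The closest evidence comes from that same carbon, where ethoxycarbonyl replacing methyl gave a 1.2-fold higher number from compound 1 to compound 3 (0.09 log units; within the scatter). Phenyl replacing isobutyl on the matching carbon gave a 1.3-fold higher number from compound 2 to compound 3 (0.12 log units; within the scatter), and the larger swap on the amide-type nitrogen gave a 1.1-fold lower number from compound 1 to compound 2 (0.03 log units; within the scatter). Among the compounds with values here, all three steps are small, but no measured compound carries ethoxymethyl, so this support is indirect. No step beyond the scatter is therefore expected in this assay, and neither direction is favoured. The expected step is no change at the digits printed from compound 3 to compound 4 (within the scatter). For compound 4 the estimated value is 16 nM, with an expected range from 7 nM to 40 nM.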

Compound 4, half-maximal inhibitory concentration: 17 nM
The estimate for compound 4 lay 1.1-fold (0.03 log units) below the measured number, and the stated range covers the measured number.
By their numbers in this assay, from the lowest: compounds 2, 1, 3 and 4 (each within the scatter of the next).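

In this assay the swap of ethoxycarbonyl for ethoxymethyl on a saturated chain carbon bound to an amide-type nitrogen and an aromatic carbon gives a 1.1-fold higher number from compound 3 to compound 4 (0.03 log units; within the scatter) and so does not separate the two compounds, even though the group that enters has one hydrogen-bond acceptor fewer and no double bond. The comparison with the methyl-bearing compound, where ethoxy stands in place of hydrogen on the chain, gives a 1.3-fold higher number from compound 1 to compound 4 (0.12 log units; within the scatter) and shows that this longer ether arm also leaves the read-out unseparated. No measurement is available to explain why these groups are so interchangeable.

All four compounds lie within the scatter of one another, so no limit to what this carbon accepts has yet appeared. An amine, a carboxylic acid or a longer chain in this place remains an open question.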